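Working notes: the step from compound 3 to compound 4

The compounds below may be only part of what the source reports. "The series", "measured", "known", "first", "only" and "open" are said of these compounds alone.

In a functional assay on PC-3 cells (Homo sapiens) for inhibition, read by MTT assay, with a stated time of 48 h, tested at 10 uM (a lower number here means less inhibition of growth, a higher number more inhibition of growth at the concentration tested), compound 1 `Cc1cc(=O)c2c(O)c(CN3CCCC3)c(O)c([C@H]3CCN(C)C[C@H]3O)c2o1` gives 10%, compound 2 `Cc1cc(=O)c2c(O)c(CN(C)CC(=O)O)c(O)c([C@H]3CCN(C)C[C@H]3O)c2o1` gives 20% and compound 3 `CCOC(=O)N1CCN(Cc2c(O)c([C@H]3CCN(C)C[C@H]3O)c3oc(C)cc(=O)c3c2O)CC1` gives 1%. Compound 3 therefore sits within the scatter of compound 1, with a number 9 percentage points lower from compound 1 to compound 3 (within the scatter). Its distance from compound 2 is larger, with a number 19 percentage points lower from compound 2 to compound 3 (beyond the scatter).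

Compound 4 `Cc1cc(=O)c2c(O)c(CN3CC(O)CC3C(=O)O)c(O)c([C@H]3CCN(C)C[C@H]3O)c2o1` differs from compound 3 in one place: 2-carboxy-4-hydroxypyrrolidin-1-yl in place of 4-(ethoxycarbonyl)piperazin-1-yl on a saturated chain carbon bound to an aromatic carbon. The entering group carries a carboxy group, as the (carboxymethyl)(methyl)amino group of compound 2 does, and a five-membered non-aromatic ring, as the pyrrolidin-1-yl group of compound 1 does. Within the data shown here, the closest evidence is a number 19 percentage points lower from compound 2 to compound 3 (beyond the scatter), which leaves the 4-(ethoxycarbonyl)piperazin-1-yl group as the one with the smaller number, while a number 10 percentage points higher from compound 1 to compound 2 (within the scatter) separates the two possible models for the new group. Among the measured compounds shown here, no measured compound carries the hydroxy group of the new ring, so the expectation remains loose. A rise somewhat smaller than the step from compound 2 is expected, stated as a number 13 percentage points higher from compound 3 to compound 4 (beyond the scatter). For compound 4 the estimated value is 14%, with an expected range of 3% to 28%.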

Compound 4, percent growth inhibition at one concentration: 0%
Compound 4: middle estimate off by 14 percentage points, on the high side, outside the stated range (below it).
By their numbers in this assay, from the lowest: compounds 4, 3, 1 and 2 (each within the scatter of the next, the first and the last beyond it).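

In this assay, a number 1 percentage points lower from compound 3 to compound 4 (within the scatter) and a number 10 percentage points lower from compound 1 to compound 4 (within the scatter) show that on the saturated chain carbon bound to an aromatic carbon, the 2-carboxy-4-hydroxypyrrolidin-1-yl group cannot be told apart from either the 4-(ethoxycarbonyl)piperazin-1-yl or the pyrrolidin-1-yl group. Carrying a carboxy group is not enough to match compound 2: a number 20 percentage points lower from compound 2 to compound 4 (beyond the scatter) is a step between two groups that both have one. No measurement at hand explains why these two carboxy-bearing groups part.

The compounds shown do not separate the carboxy group of the new ring from its hydroxy group, so a pyrrolidin-1-yl ring carrying only one of them would be the direct comparison. Also open, from the compounds shown here alone, is whether the (carboxymethyl)(methyl)amino result holds with a longer chain ending in a carboxylic acid on the same amine nitrogen.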